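One group exchanged on compound 1

The compounds below may be only part of what the source reports. "The series", "measured", "known", "first", "only" and "open" are said of these compounds alone.

Compound 1 `O=S(=O)(c1cccc(-c2ccc3ncnc(Nc4ccc(OCc5cccc(F)c5)c(Cl)c4)c3c2)c1)N1CCOCC1`: > 15000 nM (a limit)
Compound 2 `O=S(=O)(c1ccc(-c2ccc3ncnc(Nc4ccc(OCc5cc(F)cc(F)c5F)c(Cl)c4)c3c2)cc1)N1CCOCC1`: > 3000 nM (a limit)

Both compounds were tested in an ADME assay on HepG2 cells (Homo sapiens) for cytotoxicity, read by MTT assay, with a stated time of 48 h; a lower number here means a stronger inhibitor, a higher number a weaker inhibitor. Compound 1 gives > 15000 nM, which is a limit of the assay and not a number. Compound 2 gives > 3000 nM, which is also a limit. For the measured compounds named here, compound 1 therefore has no exact place on the scale, and no measured step is available as a guide.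

Compound 3 `O=C(c1cccc(-c2ccc3ncnc(Nc4ccc(OCc5cccc(F)c5)c(Cl)c4)c3c2)c1)N1CCCCC1` keeps the core of compound 1 but carries (piperidin-1-yl)carbonyl in place of (morpholin-4-yl)sulfonyl on an aromatic carbon. The only starting point for an expectation is compound 1, with its limit of > 15000 nM. No step beyond the scatter is expected in this assay, in either direction. The estimated change is a number no higher from compound 1 to compound 3 (the limit leaves the size open). For compound 3, the expected value is 15000 nM, with an estimated range from 5000 nM to 40000 nM.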

Compound 3, half-maximal inhibitory concentration: > 6000 nM
Compound 3: a limit, no number; the forecaster's own chance of this, stated with the estimate: 60%; the middle value lies beyond the limit too.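

In this assay compound 3 gives > 6000 nM, which is a limit and not a number. For the compounds shown here, compound 1 also stands at a limit, so no step from compound 1 to compound 3 can be read. The compounds shown leave open whether exchanging (morpholin-4-yl)sulfonyl for (piperidin-1-yl)carbonyl changes the cytotoxicity at all.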